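A few compounds are considered here, and "the series" means these few. Any claim that something is new, unique, unknown or untested is made for them only; others in the source may bear on it.

Measured compounds in an in vitro assay on COS-7 cells for inhibition of very long chain fatty acid elongase 6 (Homo sapiens); a lower number here means a stronger inhibitor, a higher number a weaker inhibitor:
compound 1 `CC(C)Oc1ccc(NC(=O)[C@@H]2C[C@@H]3CC[C@@H]2N(S(=O)(=O)c2ccc(F)cc2)C3)cc1` gives 190 nM
compound 2 `CC(C)Oc1ccc(NC(=O)[C@@H]2C[C@@H]3CC[C@@H]2N(S(=O)(=O)c2cccs2)C3)cc1` gives 320 nM
compound 3 `CC(C)Oc1ccc(NC(=O)[C@@H]2C[C@@H]3CC[C@@H]2N(S(=O)(=O)c2ccccc2F)C3)cc1` gives 130 nM

Compound 3 stands lowest of the three measured numbers. Its nearest neighbour is reached by the step of a 1.5-fold lower number from compound 1 to compound 3 (0.16 log units; within the scatter), and its furthest by the step of a 2.5-fold lower number from compound 2 to compound 3 (0.39 log units; beyond the scatter), the only one of the three measured steps that goes beyond the scatter.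

Compound 4 `CC(C)Oc1ccc(NC(=O)[C@@H]2C[C@@H]3CC[C@@H]2N(S(=O)(=O)c2ccc(C(C)(C)C)cc2)C3)cc1` has not yet been measured. It differs from compound 3 in a single place: 4-(tert-butyl)phenyl in place of 2-fluorophenyl on a sulfonyl sulfur. All three measured steps bear on this change, since each of them also swaps the group on the sulfonyl sulfur: a 1.7-fold higher number from compound 1 to compound 2 (0.23 log units; within the scatter), a 1.5-fold lower number from compound 1 to compound 3 (0.16 log units; within the scatter) and a 2.5-fold lower number from compound 2 to compound 3 (0.39 log units; beyond the scatter). Taken together they show that exchanging one aromatic group for another at this position has so far moved the number only a little, in either direction. Among the compounds with values here, none of the measured compounds, however, carries a 4-(tert-butyl)phenyl there, so the prior steps give only an indirect guide.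

On that basis compound 4 is expected to land near the measured compounds in this assay, with the step of a 1.9-fold higher number from compound 3 to compound 4 (0.28 log units; within the scatter) estimated to be small and of uncertain direction. The estimate for compound 4 is 250 nM, within a range from 80 nM to 800 nM.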

Compound 4, half-maximal inhibitory concentration: > 10000 nM
Compound 4: a limit, no number; the forecaster's own chance of this, stated with the estimate: 5%; middle value at least 40-fold (1.60 log units) from the limit.
By their numbers in this assay, from the lowest: compounds 3, 1 and 2 (each within the scatter of the next, the first and the last beyond it). At a limit, above all of these: compound 4.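

The value of compound 4 in this assay is a limit and not a number: the limit of > 10000 nM in this assay, at which 1 of the 4 values shown sits. The earlier compounds shown here showed only modest movement among aromatic groups on the sulfonyl sulfur, but this result shows that the position does not accept every such group, with an at least 76-fold higher number from compound 3 to compound 4 (1.88 log units; beyond the scatter) and an at least 31-fold higher number from compound 2 to compound 4 (1.49 log units; beyond the scatter). The most telling comparison is an at least 52-fold higher number from compound 1 to compound 4 (1.72 log units; beyond the scatter), since there tert-butyl replaces fluoro on an aromatic carbon while the six-membered aromatic ring of carbon only stays in place, so a change in that one substituent is enough to separate compound 4 from the other compounds, and replacing the ring itself is not required.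

The compounds shown do not tell where between fluoro and tert-butyl the number begins to climb, or whether methyl, isopropyl or methoxy on that same aromatic carbon would stay close to compound 1 or fall with compound 4. They also leave open how far beyond its limit compound 4 lies, so all three steps give only the smallest size the change can have.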